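A Benzyloxy Group Added to Two Ileum Antagonists

The compounds below may be only part of what the source reports. "The series", "measured", "known", "first", "only" and "open" are said of these compounds alone.

Compound 1 `O=C(O)c1cc(=O)c2ccc(OCCCCCOc3ccccc3)cc2o1`: 0.4 ug/mL
Compound 2 `O=C(O)c1cc(=O)c2ccc(OCCCCCOc3cccc(OCc4ccccc4)c3)cc2o1`: 1 ug/mL
Compound 3 `CCCc1ccccc1OCC(O)COc1ccc2c(=O)cc(C(=O)O)oc2c1CCC`: 0.044 ug/mL

The three measured compounds were tested in a functional assay on ileum (Cavia porcellus) for antagonist activity, with a stated time of 30 s; a higher number here means a weaker inhibitor, a lower number a stronger inhibitor. Compound 2 differs from compound 1 by benzyloxy in place of hydrogen on an aromatic carbon and this gave a 2.5-fold higher number from compound 1 to compound 2 (0.40 log units; beyond the scatter). Compound 3 carries a core whose difference from the core of compound 1 is not broken down here, and it gives the lowest number of the three in this assay.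

Compound 4 `CCCc1c(OCc2ccccc2)cccc1OCC(O)COc1ccc2c(=O)cc(C(=O)O)oc2c1CCC` has not yet been measured. It differs from compound 3 by benzyloxy in place of hydrogen on an aromatic carbon. This is the same kind of change as that from compound 1 to compound 2, though here the place is also ortho to a propyl group. Resting on the one measured step of this kind, a 2.5-fold higher number from compound 1 to compound 2 (0.40 log units; beyond the scatter), compound 4 is expected to show a 2.5-fold higher number from compound 3 to compound 4 (0.40 log units; beyond the scatter). Compound 4 is therefore estimated at 0.11 ug/mL, most likely between 0.04 ug/mL and 0.3 ug/mL.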

Compound 4, half-maximal inhibitory concentration: 1 ug/mL
Beside the measured number, compound 4's estimate is 9.1-fold (0.96 log units) below it; measured number outside the range, above it.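

In this assay the benzyloxy group gave a 23-fold higher number from compound 3 to compound 4 (1.36 log units; beyond the scatter), so the direction of the earlier step held but its size did not carry from one core to the other: the same change on two cores in this assay, a 2.5-fold higher number (0.40 log units; beyond the scatter) from compound 1 to compound 2 and a 23-fold higher number (1.36 log units; beyond the scatter) from compound 3 to compound 4, 9.1-fold (0.96 log units) apart, beyond the scatter of two such steps

Going by these compounds alone, with only one step on each core, this does not show that the cores alone set the size of the step. In compound 4 the benzyloxy group also sits ortho to a propyl group, which is not the case in compound 2, so the effects of core and place cannot be separated.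

The compounds shown leave open whether a methoxy group or an amine on the same carbon would give a similarly large step. They also leave open how benzyloxy would behave with the propyl group replaced by hydrogen.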